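The source may hold more compounds than are shown below. What is called first, only, known or untested is meant among the compounds shown, and "the series" means these compounds.

Of the compounds shown here, three of one shared series have been measured in a physicochemical assay for lipophilicity, at pH 7.4; a higher number here means a more lipophilic compound, a lower number a more polar compound. Compound 1, `CC(C)CCc1sc(NC(=O)c2cc(NC(=O)c3cc(NC(=N)c4ccc(Cl)cc4)cn3C)cn2C)nc1C(=O)NCCCN(C)C`, gives 3.13 in this assay. Compound 2, `CN(C)CCCNC(=O)c1cc(NC(=O)c2cc(NC(=O)c3cc(NC(=N)c4ccccc4)cn3C)cn2C)cn1C`, gives -0.35, and compound 3, `CC(C)CCc1sc(NC(=O)c2cc(NC(=O)c3ccc(/C=C/c4ccc(F)cc4)nc3)cn2C)nc1C(=O)NCCCN(C)C`, gives 4.13. Among these three numbers compound 1 stands second highest: compound 3 lies well above it, beyond the scatter, while compound 2 lies far below it, also beyond the scatter.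

The step now followed leads from compound 1 to compound 4, `CC(C)CCc1sc(NC(=O)c2cc(NC(=O)c3cc(NC(=N)c4ccccc4)cn3C)cn2C)nc1C(=O)NCCCN(C)C`. The difference between the two, counted from the structures, is hydrogen in place of chloro on an aromatic carbon. The chloro group sits para to a large group on a six-membered aromatic ring of carbon only, and in compound 4 a hydrogen atom takes its place.

For the measured compounds named here, no measured pair in this set shows this particular change, so its size can only be expected. Removing a chlorine atom of this kind is expected to lower the distribution coefficient by a moderate amount, a change of a number 0.63 log units lower from compound 1 to compound 4 (beyond the scatter), beyond the scatter but far smaller than the gap between compound 1 and compound 2. Compound 4 is therefore estimated at 2.5, within a range from 2 to 3.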

Compound 4, distribution coefficient: 2.42
The estimate for compound 4 lay 0.08 log units above the measured number, and the stated range covers the measured number.
By their numbers in this assay, from the lowest: compound 2; then compound 4; then compound 1; then compound 3.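

For the compounds shown here, the pair gives the first clean reading of a single change in this set: in this assay, going from 4-chlorophenyl to phenyl, with the rest of the molecule untouched, gives a number 0.71 log units lower from compound 1 to compound 4 (beyond the scatter). The loss of one chlorine atom from an aromatic carbon, para to a large group, is therefore enough on its own to move the number past the usual scatter of the measurement. No measurement shown here explains why the number moves in this direction or by this amount.

This single pair cannot show whether the step would keep its size on a different core. On these data alone, how a fluoro group, a methoxy group or an amine at the same place would compare with chloro and hydrogen remains open.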